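The source may hold more compounds than are shown below. What is called first, only, known or untested is meant among the compounds shown, and "the series" means these compounds.

Of the compounds shown here, two that share one core have been measured in an in vitro ADME assay on microsomes (Homo sapiens) for metabolic stability; on this read-out lower numbers stand for slow clearance and higher numbers for fast clearance. Compound 2 (`O=C(CN(CC1CCC1)C(=O)c1ccc(-c2ccccn2)cc1)Nc1cc(F)cc(F)c1`), with cyclobutylmethyl on an amide-type nitrogen, gives 2 mL.min-1.g-1, and compound 1 (`O=C(CN(C(=O)c1ccc(-c2ccccn2)cc1)C1CCCOC1)Nc1cc(F)cc(F)c1`), with oxan-3-yl at that nitrogen, gives 2.9 mL.min-1.g-1. Going by the values given here, these two values lie within the scatter of each other, so compound 2 stands level with the only other number available.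

Compound 3 (`CCC(COC)N(CC(=O)Nc1cc(F)cc(F)c1)C(=O)c1ccc(-c2ccccn2)cc1`) has not yet been measured. It carries 1-(methoxymethyl)propyl in place of cyclobutylmethyl on an amide-type nitrogen.

Among the compounds with values here, only one measured step bears on this change, since it is the only one made at the same nitrogen: a 1.5-fold lower number from compound 1 to compound 2 (0.16 log units; within the scatter). That single step stayed within the scatter, which is thin evidence, but nothing in the data points to a larger move. No step beyond the scatter is therefore expected in this assay, and the estimated change is a 1.4-fold higher number from compound 2 to compound 3 (0.13 log units; within the scatter). For compound 3 the estimated value is 2.7 mL.min-1.g-1, with an expected range from 1.3 mL.min-1.g-1 to 5.5 mL.min-1.g-1.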

Compound 3, intrinsic clearance in microsomes: 9.6 mL.min-1.g-1
Compound 3: the middle estimate sits 3.6-fold (0.55 log units) below what was measured; the whole stated range lies below it.
By their numbers in this assay, from the lowest: compounds 2 and 1 (each within the scatter of the next); then compound 3.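

In this assay the amide-type nitrogen proves sensitive to what it carries: 1-(methoxymethyl)propyl gives a 4.8-fold higher number from compound 2 to compound 3 (0.68 log units; beyond the scatter) and also a 3.3-fold higher number from compound 1 to compound 3 (0.52 log units; beyond the scatter) while cyclobutylmethyl and oxan-3-yl had stayed within the scatter of each other. Among these three compounds the higher number goes with the only group that has no ring, and oxygen alone does not sort them, since compound 1 also carries an oxygen in its oxan-3-yl group yet stands level with compound 2 rather than with compound 3. No measurement shown here explains why the number rises with this change.

The three compounds leave open whether the higher number follows the open chain itself or its methoxymethyl arm, since 1-(methoxymethyl)propyl brings both at once. A plain sec-butyl group, which keeps an open chain without the ether oxygen, or a 2-methoxyethyl group, which keeps the ether on a shorter chain, would pull these two apart, and an amine such as a piperidin-4-yl group at the same nitrogen remains an untested kind of substituent in this set.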